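Nitro-to-amino change in a sulfone series: cytotoxicity notes

The compounds below may be only part of what the source reports. "The series", "measured", "known", "first", "only" and "open" are said of these compounds alone.

Compound 1 `COc1cc(/C=C/S(=O)(=O)Cc2ccc(OC)c([N+](=O)[O-])c2)cc(OC)c1` and compound 2 `COc1ccc(CS(=O)(=O)CC(=O)Nc2ccccc2)cc1[N+](=O)[O-]` share a nitro-bearing methoxyphenyl sulfone, and the difference between the two cores is not broken down here. In an ADME assay on MRC5 cells (Homo sapiens) for cytotoxicity, read by MTT assay, with a stated time of 72 h (a higher number here means a weaker inhibitor of growth, a lower number a stronger inhibitor of growth), compound 1 gives only a limit, > 30000 nM. Compound 2 likewise gives only a limit in this assay, > 30000 nM. Compound 3 `COc1ccc(CS(=O)(=O)CC(=O)Nc2ccccc2)cc1N` carries amino in place of nitro on an aromatic carbon; in this assay compound 3 also gives only a limit, > 30000 nM. The step that the two limits leave unreadable from compound 2 to compound 3 is therefore unreadable, resting on (the limit of > 30000 nM in this assay, at which 3 of the 3 values shown sit). Compound 4 `COc1cc(/C=C/S(=O)(=O)Cc2ccc(OC)c(N)c2)cc(OC)c1` carries the same change relative to compound 1, (amino in place of nitro on an aromatic carbon), at the same place. On the evidence of compound 3 at > 30000 nM, compound 4 is expected to sit at 40000 nM in this assay. The expected step that the limit leaves unreadable from compound 1 to compound 4 is thus flat, most likely again reported only as a limit.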

Compound 4, concentration for 50% growth inhibition: > 30000 nM
Compound 4 gave a limit, no number; the forecaster's own chance of this, stated with the estimate: 85%; the middle value is on the limit's open side.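

No step can be read from compound 1 to compound 4, as both give only a limit in this assay: the limit of > 30000 nM in this assay, at which 4 of the 4 values shown sit. The compounds shown leave open whether amino in place of nitro alters growth inhibition in this assay on either core.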